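Phenyl in place of furan on a shared core

The source may report more compounds than this note shows. Statements on the series, on what has been measured and on what is new or still open speak of the compounds shown alone.

Within the data shown here, compound 1 `O=c1[nH]cnc2c1c(-c1ccoc1)cn2[C@@H]1O[C@H](CO)[C@@H](O)[C@H]1O` is the only compound here with a number in a functional assay on CCRF-CEM cells (Homo sapiens), read by MTT assay, with a stated time of 72 h; a lower number here means a stronger inhibitor, a higher number a weaker inhibitor: compound 1 gives 9030 nM. Compound 2 `CSc1ncnc2c1c(-c1ccsc1)cn2[C@@H]1O[C@H](CO)[C@@H](O)[C@H]1O` reaches only a limit of the assay, > 20000 nM, in this assay. Compound 2 sits at the limit of > 20000 nM in this assay, at which 1 of the 2 values shown sits. Compound 3 `O=c1[nH]cnc2c1c(-c1ccccc1)cn2[C@@H]1O[C@H](CO)[C@@H](O)[C@H]1O` differs from compound 1 by one change: phenyl in place of furan-3-yl on an aromatic carbon. No measured step of this kind is shown, so the step from compound 1 to compound 3 is expected to stay within the scatter or lean slightly toward weaker inhibition, estimated as a 1.2-fold higher number from compound 1 to compound 3 (0.09 log units; within the scatter). Compound 3 is expected to give about 11000 nM in this assay, between 4000 nM and 28000 nM.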

Compound 3, half-maximal inhibitory concentration: > 100000 nM
Compound 3 was reported as a limit; the forecaster's own chance of this, stated with the estimate: 35%; middle value at least 9.0-fold (0.95 log units) away from the limit.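

In this assay, the group on this aromatic carbon clearly matters: phenyl in place of furan-3-yl gives an at least 11-fold higher number from compound 1 to compound 3 (1.04 log units; beyond the scatter), a large weakening that compounds 1 and 2, which differ in more than one place, could not reveal. Compound 3 gives only a limit of the assay, not a number: the limit of > 100000 nM in this assay, at which 1 of the 3 values shown sits.

As far as these compounds go, whether ring size or the loss of the ring oxygen drives this change stays open. A pyridin-3-yl group on this carbon, a six-membered ring carrying a nitrogen, would help separate the two.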